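Substituent changes on one aromatic carbon: series notes

A few compounds are considered here, and "the series" means these few. Any claim that something is new, unique, unknown or untested is made for them only; others in the source may bear on it.

Measured in a functional assay on the whole organism with Mus musculus as the target (a higher number here means a more potent compound, by a factor of ten per unit of this negative logarithm, a lower number a less potent compound), so far:
- compound 1, `Cc1ccc(C(=O)OC2CCN(C)CC2)cc1`: 1.17
- compound 2, `CN1CCC(OC(=O)c2ccc(C(C)(C)C)cc2)CC1`: 1.13
- compound 3, `CN1CCC(OC(=O)c2ccc([N+](=O)[O-])cc2)CC1`: 1.14

The three compounds share one core and differ only in the group on a single aromatic carbon. In this assay compound 3 holds the second highest of the three numbers. Its nearest neighbour is compound 2: a number 0.01 log units higher from compound 2 to compound 3 (within the scatter). The furthest is compound 1: a number 0.03 log units lower from compound 1 to compound 3 (within the scatter). The remaining pair behaves the same way: a number 0.04 log units lower from compound 1 to compound 2 (within the scatter). Going by the values given here, each step so far swaps the group on that aromatic carbon for a different one, and none of the three moves the number beyond the scatter.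

The next compound, compound 4, `CN1CCC(OC(=O)c2ccc(F)cc2)CC1`, continues this exchange: fluoro in place of nitro on an aromatic carbon. All three measured steps bear on it, since each replaces one group on the same aromatic carbon with another, and each was small. No step beyond the scatter is therefore expected in this assay; the expected change is a number 0.01 log units higher from compound 3 to compound 4 (within the scatter), in no particular direction.

On that basis compound 4 is estimated at 1.15 in this assay, within a range of 0.85 to 1.45.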

Compound 4, logarithm of the reciprocal of the active concentration, log(1/C): 1.38
Estimate against measurement, compound 4: 0.23 log units below, and the stated range covers the measured number.
By their numbers in this assay, from the lowest: compounds 2, 3, 1 and 4 (each within the scatter of the next).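

In this assay the step of a number 0.24 log units higher from compound 3 to compound 4 (within the scatter) stands with a number 0.25 log units higher from compound 2 to compound 4 (within the scatter) and with a number 0.21 log units higher from compound 1 to compound 4 (within the scatter) and these three are each larger than any earlier step on this aromatic carbon, yet all remain within the scatter. Fluoro brings a single heavy atom where nitro has 3 heavy atoms, and even this exchange separates no pair among methyl, tert-butyl, nitro and fluoro, so this position, para to a large group, has still given no step beyond the scatter in either direction. No measurement at hand bears on what lies behind the size of these steps.

On these data alone, whether any group on this carbon can produce a step beyond the scatter stays open, and an amine, a carboxylic acid or a longer chain such as n-hexyl would test this on the shared core. Also open, as far as these compounds go, is whether fluoro on another aromatic carbon of the ring, rather than para to a large group, would give a number within the scatter of those seen here.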